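Methoxy for fluoro on the aryl ring of compound 2

The source may report more compounds than this note shows. Statements on the series, on what has been measured and on what is new or still open speak of the compounds shown alone.

Within the data shown here, compound 2 `O=C(/C=C\Nc1ccc(F)cc1)c1cn(-c2ccccc2)nc1-c1ccc(F)cc1` gives 18200 nM in a functional assay on U-87MG ATCC cells (Homo sapiens) for antiproliferative activity, read by MTT assay, with a stated time of 48 h (a lower number here means a stronger inhibitor, a higher number a weaker inhibitor), the highest of the three numbers measured so far. Compound 1 `O=C(/C=C\Nc1ccc(F)cc1)c1cn(-c2ccccc2)nc1-c1ccccc1` gives 10200 nM in this assay, and the step is a 1.8-fold higher number from compound 1 to compound 2 (0.25 log units; within the scatter). Compound 3 `O=C(/C=C\Nc1ccc(Cl)cc1)c1cn(-c2ccccc2)nc1-c1ccc(F)cc1` gives 8900 nM in this assay, reached by a 2.0-fold lower number from compound 2 to compound 3 (0.31 log units; beyond the scatter), a change on the other aryl ring.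

Compound 4 `COc1ccc(-c2nn(-c3ccccc3)cc2C(=O)/C=C\Nc2ccc(F)cc2)cc1` differs from compound 2 by methoxy in place of fluoro on an aromatic carbon. Among the measured compounds shown here, the only measured step at this position is the one from compound 1 to compound 2, hydrogen to fluoro, which stayed within the scatter; the step from compound 2 to compound 3 sits on the other ring and shows only the scale of change seen so far. Both steps are small, so for compound 4 no step beyond the scatter is expected in this assay, with a slight lean toward a lower number since compound 2 is the highest point. Compound 4 is therefore estimated at 13000 nM in this assay, range 5000 nM to 40000 nM, a step of a 1.4-fold lower number from compound 2 to compound 4 (0.15 log units; within the scatter).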

Compound 4, half-maximal inhibitory concentration: 8910 nM
Compound 4: middle estimate off by 1.5-fold (0.16 log units), on the high side; measured number inside the range.
By their numbers in this assay, from the lowest: compounds 3, 4, 1 and 2 (each within the scatter of the next, the first and the last beyond it).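

In this assay, among these compounds, the change from 4-fluorophenyl to 4-methoxyphenyl gives a 2.0-fold lower number from compound 2 to compound 4 (0.31 log units; beyond the scatter) and is the first step at this position to pass the scatter, though only modestly. Methoxy in place of hydrogen gives a 1.1-fold lower number from compound 1 to compound 4 (0.06 log units; within the scatter) and so separates nothing, which means that among the three groups tried here only the fluoro and methoxy compounds, compound 2 and compound 4, stand apart, while compound 1 lies within the scatter of both. Nothing available here accounts for this step.

As far as these compounds go, whether an amine or a longer chain such as ethoxy at this position would move the number further remains open. Also open, from the compounds shown here alone, is whether methoxy in place of fluoro gives a step of similar size when the other aryl ring carries the chloro of compound 3.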